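This account rests on a few compounds, and the source may have more. Where it says the series, first, only, none or still open, it means among the compounds named here.

Measured compounds in a functional assay on the whole organism (B cells) with Mus musculus as the target; on this read-out higher numbers stand for larger maximal responses and lower numbers for smaller maximal responses:
- compound 1, `C=CCn1c(=O)n(CCC(CCOCc2ccccc2)CCOCc2ccccc2)c2nc(N)nc(O)c21`, gives 68%
- compound 2, `CCCCCCCCCCn1c(=O)n(C2OC(CO)[C@@H](O)[C@H]2O)c2nc(N)nc(O)c21`, gives 0%
- compound 3, `CC1OC(n2c(=O)n(C)c3c(O)nc(N)nc32)[C@H](O)[C@@H]1O`, gives 0%

Compound 2 stands, in this assay, level with compound 3 at the digits shown; together they are the lowest of the three numbers, and the pair lies within the scatter of each other, so no order is read between them. The furthest number is that of compound 1, which lies higher by a margin that is beyond the scatter.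

The next compound, compound 4, `N#Cc1cccc(Cn2c(=O)n(C3OC(CO)[C@@H](O)[C@H]3O)c3nc(N)nc(O)c32)c1`, has not been measured in this assay. It differs from compound 2 in one place: 3-cyanophenyl in place of nonyl on a saturated chain carbon bound to an aromatic nitrogen. Within the data shown here, no step between two measured compounds isolates this kind of change, so its direction in this assay is not fixed by the data. Among the measured compounds shown here, the numbers show only that compound 2 sits at the bottom of the range and that compound 1, carrying long substituted chains with benzyl groups, sits well above it.

Compound 4 is therefore expected to give 20% in this assay, within a range from 0% to 55%. The estimated step of a number 20 percentage points higher from compound 2 to compound 4 (beyond the scatter) is expected to be modest and upward, but with wide uncertainty.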

Compound 4, largest response reached (reported as maximal response), in percent of the reference or control that the assay uses: 16%
For compound 4 the middle estimate is 4 percentage points above the measured one, and the stated range covers the measured number.
By their numbers in this assay, from the lowest: compounds 2 and 3 (each within the scatter of the next); then compound 4; then compound 1.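

In this assay, the saturated chain carbon bound to an aromatic nitrogen is now shown to be a place where a single change moves the number: 3-cyanophenyl in place of nonyl gives a number 16 percentage points higher from compound 2 to compound 4 (beyond the scatter). The shared core bearing this sugar is therefore not tied to the bottom of the range, since compound 4 reaches 16% where compound 2 gives 0%, although the step is modest and compound 4 rests on one change at one position. No supporting data bear on what lies behind this step.

The change swaps a chain for an aromatic ring and adds a nitrile in one move, so the compounds shown do not tell which of these accounts for the step; plain benzyl in place of 3-cyanobenzyl would separate the ring from the nitrile. On these data alone, whether chain length at this place matters at all also stays open, and a butyl group or a chain ending in an amine, set against decyl on the same core, would address it.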